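Removing the Chloro Group from Compound 3

A few compounds are considered here, and "the series" means these few. Any claim that something is new, unique, unknown or untested is made for them only; others in the source may bear on it.

Values in a functional assay on HeLa cells (Homo sapiens) for antiproliferative activity, read by MTT assay, with a stated time of 48 h; on this read-out higher numbers stand for weaker inhibition and lower numbers for stronger inhibition:
compound 1 `Clc1ccccc1CSc1nnc(-c2cnccn2)s1` gives 28900 nM
compound 2 `Brc1cccc(CSc2nnc(-c3cnccn3)s2)c1` gives 5430 nM
compound 3 `Clc1ccc(CSc2nnc(-c3cnccn3)s2)cc1` gives 18900 nM

Among these three compounds, compound 3 at 18900 nM lies within the usual scatter of compound 1 at 28900 nM. Compound 2 at 5430 nM gives a lower number than compound 3, and that gap lies beyond the scatter.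

The next compound to be tested is compound 4 `c1ccc(CSc2nnc(-c3cnccn3)s2)cc1`. It has hydrogen in place of chloro on an aromatic carbon, at a place on an aromatic carbon of a six-membered aromatic ring of carbon only, para to a large group (hydrogen in place of chloro on an aromatic carbon). Among the compounds with values here, no two measured compounds differ in one place alone, so the data give no direct measure of this change. The expectation therefore rests on the range of the measured values, from compound 2 at 5430 nM to compound 1 at 28900 nM, with compound 3 as the starting point. In this assay no change beyond the scatter is expected, and the estimated 1.1-fold higher number from compound 3 to compound 4 (0.02 log units; within the scatter) has no favoured direction. Compound 4 is expected to give an estimated 20000 nM (range 7000 nM to 60000 nM).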

Compound 4, half-maximal inhibitory concentration: 34400 nM
For compound 4 the middle estimate is 1.7-fold (0.24 log units) below the measured one, within the range that was stated.
By their numbers in this assay, from the lowest: compound 2; then compounds 3, 1 and 4 (each within the scatter of the next).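

In this assay the exchange of chloro for hydrogen at this place, para to a large group on the six-membered aromatic ring of carbon only, now has a direct reading: a 1.8-fold higher number from compound 3 to compound 4 (0.26 log units; within the scatter) shows that chloro here can give way to hydrogen with no difference that stands clear of the scatter. The same exchange from the chloro compound with its group at another place is a 1.2-fold higher number from compound 1 to compound 4 (0.08 log units; within the scatter) and also stays within the scatter, while hydrogen in place of bromo is a 6.3-fold higher number from compound 2 to compound 4 (0.80 log units; beyond the scatter) and is a modest step beyond it, so among these compounds only the bromo compound 2 stands apart from compound 4. Nothing available gives a reason for either outcome.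

The compounds shown do not separate the effect of the bromo group itself from that of its place on the ring, since no pair here has bromo and chloro at the same place. They also leave open whether a larger or different group at the place held by chloro in compound 3, such as an amine, a methoxy group or a carboxylic acid, would move the number away from that of compound 4.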